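The compounds below may be only part of what the source reports. "The series", "measured", "known", "first", "only" and "open" are said of these compounds alone.

Measured compounds, with their numbers in a physicochemical assay for permeability, using PAMPA, at pH 7.4; a higher number here means that the compound crosses the layer faster, a lower number that the compound crosses the layer more slowly:

Compound 1, `CC(C)(C)NC(=O)NCCS(=O)(=O)NC(=O)c1ccc(Nc2nc(NC3(c4ccc(Cl)cc4)CC3)nc(OCC(F)(F)F)n2)cc1` — compound 1 gives 49 nm/s.
Compound 2, `CC(C)(C)OC(=O)NCCS(=O)(=O)NC(=O)c1ccc(Nc2nc(NC3(c4ccc(Cl)cc4)CC3)nc(OCC(F)(F)F)n2)cc1` — compound 2 gives 111 nm/s.
Compound 3, `CC(C)NC(=O)NCCS(=O)(=O)NC(=O)c1ccc(Nc2nc(NC3(c4ccc(Cl)cc4)CC3)nc(OCC(F)(F)F)n2)cc1` — compound 3 gives 45 nm/s.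

Compound 3 has the lowest number of the three, though its gap to compound 1 is within the scatter; only compound 2 stands clearly apart, as a 2.5-fold lower number from compound 2 to compound 3 (0.39 log units; beyond the scatter) shows. The measured steps all concern the cap on the urea or carbamate: a 2.3-fold higher number from compound 1 to compound 2 (0.36 log units; beyond the scatter) and a 1.1-fold lower number from compound 1 to compound 3 (0.04 log units; within the scatter). The acylsulfonamide-linked chain itself is kept throughout.

Compound 4, `CS(=O)(=O)NC(=O)c1ccc(Nc2nc(NC3(c4ccc(Cl)cc4)CC3)nc(OCC(F)(F)F)n2)cc1`, takes a different step: hydrogen in place of ((isopropylcarbamoyl)amino)methyl on a saturated chain carbon bound to a sulfonyl sulfur. Among the compounds with values here, no measured pair covers the loss of this chain, so the steps above bear on it only indirectly: they show that changing the cap at the end of the chain moves the number by a modest amount or not beyond the scatter. Removing the chain altogether is a larger change than any measured here, and its direction can only be guessed.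

The expectation for compound 4 is a modest increase, a 2.7-fold higher number from compound 3 to compound 4 (0.43 log units; beyond the scatter), with wide uncertainty. Compound 4 is therefore estimated at 120 nm/s, in the range 40 nm/s to 350 nm/s.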

Compound 4, apparent permeability: 11 nm/s
Estimate against measurement, compound 4: 11-fold (1.04 log units) above; the measured number lies below the stated range.
By their numbers in this assay, from the lowest: compound 4; then compounds 3 and 1 (each within the scatter of the next); then compound 2.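

In this assay, the loss of the capped chain on the saturated chain carbon bound to a sulfonyl sulfur gives a 4.1-fold lower number from compound 3 to compound 4 (0.61 log units; beyond the scatter) and a 4.5-fold lower number from compound 1 to compound 4 (0.65 log units; beyond the scatter) and also a 10-fold lower number from compound 2 to compound 4 (1.00 log units; beyond the scatter) with all three steps in the same direction. The earlier compounds shown here showed only that the cap can shift the number modestly or leave it within the scatter, whereas these steps show that the presence of the chain itself matters, with compound 4 clearly lowest of the four and each cap on the chain giving a higher number than methylsulfonyl alone. Nothing at hand accounts for the drop, so only its direction and size can be stated.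

From the compounds shown here alone, it remains open whether the higher numbers follow from the chain or depend on its urea or carbamate cap, a question that a plain ethylsulfonyl or a (2-aminoethyl)sulfonyl group in place of methylsulfonyl would address. Going by these compounds, it is also open how a longer chain, or a carboxylic acid in place of the cap, would sit against the numbers seen so far.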